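Methyl for trifluoromethyl in dichloroacetanilides: a second instance

The source may report more compounds than this note shows. Statements on the series, on what has been measured and on what is new or still open speak of the compounds shown alone.

Compound 1 `O=C(Nc1cccc(-c2ccccc2C(F)(F)F)c1)C(Cl)Cl` and compound 3 `O=C(Nc1cccc(-c2cccc(C(F)(F)F)c2)c1)C(Cl)Cl` share the same atoms joined differently; the difference between the two cores is not broken down here. In a functional assay on NCI-H460 cells (Homo sapiens) for cytotoxicity, read by MTT assay, with a stated time of 68 h (on this read-out higher numbers stand for weaker inhibition and lower numbers for stronger inhibition), compound 1 gives 7550 nM, compound 3 gives 30200 nM, and compound 2 `Cc1ccccc1-c1cccc(NC(=O)C(Cl)Cl)c1` gives 31600 nM. The step of a 4.2-fold higher number from compound 1 to compound 2 (0.62 log units; beyond the scatter) came from methyl in place of trifluoromethyl on an aromatic carbon. Compound 4 `Cc1cccc(-c2cccc(NC(=O)C(Cl)Cl)c2)c1` is not yet measured; it differs from compound 3 by methyl in place of trifluoromethyl on an aromatic carbon. This is the same kind of change, not the same: in compound 1 the group sits ortho to a large group, in compound 3 meta to a large group. Resting on a 4.2-fold higher number from compound 1 to compound 2 (0.62 log units; beyond the scatter), compound 4 is expected to show a step of about a 3.0-fold higher number from compound 3 to compound 4 (0.47 log units; beyond the scatter) in this assay. The estimate for compound 4 is 90000 nM, between 30000 nM and 250000 nM.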

Compound 4, half-maximal inhibitory concentration: 24300 nM
The estimate for compound 4 lay 3.7-fold (0.57 log units) above the measured number; the whole stated range lies above it.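

In this assay, methyl in place of trifluoromethyl on the core of compound 3 gave a 1.2-fold lower number from compound 3 to compound 4 (0.09 log units; within the scatter), so the change has no readable effect on this core. The size of the step therefore did not carry from one core to the other: the same change on two cores in this assay, a 4.2-fold higher number (0.62 log units; beyond the scatter) from compound 1 to compound 2 and a 1.2-fold lower number (0.09 log units; within the scatter) from compound 3 to compound 4, 5.2-fold (0.72 log units) apart, beyond the scatter of two such steps. For the compounds shown here, with only two pairs, this shows that the step depends on the core but does not show why, and it cannot say how the change would behave on any further core.

The compounds shown carry only methyl or trifluoromethyl on this ring. On these data alone, how an amine, a methoxy group or a carboxylic acid in that place would read in this assay remains open.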